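The compounds below may be only part of what the source reports. "The series", "measured", "known", "first", "only" and "open" are said of these compounds alone.

Compound 1 `CC(C)Oc1cc(=O)oc2cc(OCc3cccc(Cl)c3)ccc12` in an assay on isolated protein (strain Sprague-Dawley) for inhibition of Amine oxidase [flavin-containing] B (Rattus norvegicus), read by spectrophotometry, with a stated time of 5 min; a lower number here means a stronger inhibitor, a higher number a weaker inhibitor: 24500 nM
Compound 2 `CNC(=O)COc1cc(=O)oc2cc(OCc3cccc(Cl)c3)ccc12` in this assay: 33.9 nM
Compound 3 `CCOC(=O)c1cc(=O)oc2cc(OCc3cccc(Cl)c3)ccc12` in this assay: 417 nM

Compound 3 stands second highest of the three numbers. The nearest neighbour is given by a 12-fold higher number from compound 2 to compound 3 (1.09 log units; beyond the scatter); the furthest by a 59-fold lower number from compound 1 to compound 3 (1.77 log units; beyond the scatter).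

Compound 4 `NC(=O)c1cc(=O)oc2cc(OCc3cccc(Cl)c3)ccc12` differs from compound 3 by amino in place of ethoxy on a carbonyl carbon, so the ester becomes a primary amide. Going by the values given here, two measured steps bear on this: a 720-fold lower number from compound 1 to compound 2 (2.86 log units; beyond the scatter), in which a (methylcarbamoyl)methyl group entered, and a 12-fold higher number from compound 2 to compound 3 (1.09 log units; beyond the scatter), in which the (methylcarbamoyl)methoxy group gave way to the ester. In both, the compound carrying the carbamoyl unit gave the lower number, by a large margin. A lower number for compound 4 is therefore expected, a 7.0-fold lower number from compound 3 to compound 4 (0.84 log units; beyond the scatter). Compound 4 is estimated at 60 nM, with a range from 15 nM to 250 nM.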

Compound 4, half-maximal inhibitory concentration: 234 nM
Compound 4: the middle estimate sits 3.9-fold (0.59 log units) below what was measured; low and high end bracket the measured number.
By their numbers in this assay, from the lowest: compound 2; then compounds 4 and 3 (each within the scatter of the next); then compound 1.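

In this assay the change from ethoxy to amino on the carbonyl carbon gives a 1.8-fold lower number from compound 3 to compound 4 (0.25 log units; within the scatter) and so does not separate the ester from the primary amide, which means a carbamoyl group on this carbon does not by itself reach the lowest number in the series. Carbamoyl in place of (methylcarbamoyl)methoxy gives a 6.9-fold higher number from compound 2 to compound 4 (0.84 log units; beyond the scatter) and carbamoyl in place of isopropoxy gives a 100-fold lower number from compound 1 to compound 4 (2.02 log units; beyond the scatter), so both groups keep their distance from it. No measurement here explains these steps.

Open, as far as these compounds go, is how a methylamide on the same carbonyl carbon would read. From the compounds shown here alone, a carboxylic acid there is equally open, as is a primary amide on a longer chain.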